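Phenyl to Oxazolyl: Expected Solubility of Compound 4

This account rests on a few compounds, and the source may have more. Where it says the series, first, only, none or still open, it means among the compounds named here.

Compound 1 `CC(C)Cc1ncc2c(N)c(C#N)c(N)nc2n1` gives 268000 nM in a physicochemical assay for solubility, in phosphate buffer, with a stated time of 18 h; on this read-out higher numbers stand for higher solubility and lower numbers for lower solubility.
Compound 2 `CC(C)(C)c1nc(CCCCCC#N)c2c(N)c(C#N)c(N)nc2n1` gives 6000 nM in this assay.
Compound 3 `CC(C)(C)c1nc(-c2ccccc2)c2c(N)c(C#N)c(N)nc2n1` gives 4000 nM in this assay.

Compound 3 has the lowest of the three numbers, though its gap to compound 2 is within the scatter, while compound 1 stands far higher. Compound 4 `CC(C)(C)c1nc(-c2ncco2)c2c(N)c(C#N)c(N)nc2n1` differs from compound 3 in one place: 1,3-oxazol-2-yl in place of phenyl on an aromatic carbon. Within the data shown here, only one measured step bears on this place, a 1.5-fold lower number from compound 2 to compound 3 (0.18 log units; within the scatter), and it did not involve the oxazolyl group. Among the measured compounds shown here, no measured step shows a large shift from a change at this place. Compound 4 is therefore expected to give about 8000 nM, estimated between 3000 nM and 25000 nM. This estimate means an expected step of a 2.0-fold higher number from compound 3 to compound 4 (0.30 log units; within the scatter), close to the scatter.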

Compound 4, solubility: 50000 nM
Beside the measured number, compound 4's estimate is 6.3-fold (0.80 log units) below it; the whole stated range lies below it.
By their numbers in this assay, from the lowest: compounds 3 and 2 (each within the scatter of the next); then compound 4; then compound 1.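

In this assay, 1,3-oxazol-2-yl in place of phenyl gives a 13-fold higher number from compound 3 to compound 4 (1.10 log units; beyond the scatter) and so shows that a change at this place on the shared core can move the number beyond the scatter, which the earlier step here did not. Set against 5-cyanopentyl at the same place, the same group gives an 8.3-fold higher number from compound 2 to compound 4 (0.92 log units; beyond the scatter) and stands above both groups measured there. Nothing measured here explains this rise.

Still open, as far as these compounds go, is whether other five-membered aromatic rings, such as a thiazole or an imidazole, would give a similar number. From the compounds shown here alone, what an amine or a carboxylic acid would do at this place also remains unknown.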